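Cyclopropylcarbonyl in place of furoyl on the isopentyl analogue

The source may report more compounds than this note shows. Statements on the series, on what has been measured and on what is new or still open speak of the compounds shown alone.

Three compounds of this series have been run in an assay on isolated protein for inhibition of aldehyde dehydrogenase 1A1 (Homo sapiens), read by spectrophotometry, tested at 10 uM; a higher number here means more inhibition at the concentration tested (going by the name of the read-out), a lower number less inhibition. Compound 2 `CC(C)CCn1c(CN2CCN(C(=O)c3ccco3)CC2)nc2ccccc21` gives 42.1%, the highest of the three numbers. Compound 1 `CCn1c(CN2CCN(C(=O)C3CC3)CC2)nc2ccccc21` gives 20.8%, and compound 3 `Cc1cccc(Cn2c(CN3CCN(C(=O)c4ccncc4)CC3)nc3ccccc32)c1` gives 20.6%; both steps down from compound 2 lie beyond the scatter. Compound 4 `CC(C)CCn1c(CN2CCN(C(=O)C3CC3)CC2)nc2ccccc21` has not yet been measured. It differs from compound 2 in one place: cyclopropyl in place of furan-2-yl on a carbonyl carbon. Going by the values given here, no measured pair shows this change on its own. Compound 1, which also carries the cyclopropylcarbonyl, gives 20.8%, so a drop beyond the scatter from compound 2 to compound 4 is expected, though not the whole way down. The expected step is a number 14.1 percentage points lower from compound 2 to compound 4 (beyond the scatter). Compound 4 is estimated at 28%, with a range from 12% to 45%.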

Compound 4, a percentage reported as inhibition, at one concentration (the size of the read-out at that concentration, not a potency): 70%
Beside the measured number, compound 4's estimate is 42 percentage points below it; the measured number lies above the stated range.
By their numbers in this assay, from the lowest: compounds 3 and 1 (each within the scatter of the next); then compound 2; then compound 4.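

In this assay, cyclopropyl in place of furan-2-yl on the carbonyl carbon gives a number 27.9 percentage points higher from compound 2 to compound 4 (beyond the scatter), so this acyl change raises the number on the isopentyl analogue rather than lowering it. With the cyclopropylcarbonyl held constant, isopropyl in place of hydrogen on the saturated chain carbon gives a number 49.2 percentage points higher from compound 1 to compound 4 (beyond the scatter), which shows that the low number of compound 1 does not carry over to the longer chain. Nothing available accounts for either step.

As far as these compounds go, whether the acyl change gives a similar step on the ethyl chain of compound 1 remains open. So does the effect of a cyclobutylcarbonyl or a longer chain.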